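Removing the Methyl from a Methoxy Group

The compounds below may be only part of what the source reports. "The series", "measured", "known", "first", "only" and "open" are said of these compounds alone.

Of the compounds shown here, three sharing one core have been tested in a functional assay on HepG2 cells (Homo sapiens) for cytotoxicity, read by MTT assay, with a stated time of 48 h; a higher number here means a weaker inhibitor, a lower number a stronger inhibitor. Compound 1 `Cc1ncc([N+](=O)[O-])n1CCSc1nnc(-c2ccccc2)o1` gives 17500 nM. Compound 2 `COc1ccccc1-c1nnc(SCCn2c([N+](=O)[O-])cnc2C)o1` gives 10000 nM, and compound 3 `Cc1ncc([N+](=O)[O-])n1CCSc1nnc(-c2ccccc2Cl)o1` gives 15600 nM. Compound 2 has the lowest of the three numbers, yet the step of a 1.8-fold lower number from compound 1 to compound 2 (0.24 log units; within the scatter) and the step of a 1.6-fold higher number from compound 2 to compound 3 (0.19 log units; within the scatter) both fall within the scatter, so no order among the three can be claimed. Compound 4 `Cc1ncc([N+](=O)[O-])n1CCSc1nnc(-c2ccccc2O)o1` differs from compound 2 at a single point: hydrogen in place of methyl on an oxygen on an aromatic ring. Within the data shown here, no measured pair shows this same change. The steps that touch this part of the structure are the step of a 1.8-fold lower number from compound 1 to compound 2 (0.24 log units; within the scatter) and the step of a 1.6-fold higher number from compound 2 to compound 3 (0.19 log units; within the scatter), and neither left the scatter. Changes at this position have so far produced no clear movement in this assay, and a step beyond the scatter is therefore not expected in either direction. For compound 4 the estimate is 12000 nM, with a range from 5000 nM to 30000 nM. The expected step is a 1.2-fold higher number from compound 2 to compound 4 (0.08 log units; within the scatter).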

Compound 4, half-maximal inhibitory concentration: 19600 nM
Estimate against measurement, compound 4: 1.6-fold (0.21 log units) below, and the stated range covers the measured number.
By their numbers in this assay, from the lowest: compounds 2, 3, 1 and 4 (each within the scatter of the next).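

Among these compounds, removing the methyl gives the first direct reading of this change, and a 2.0-fold higher number from compound 2 to compound 4 (0.29 log units; within the scatter) remains within the scatter in this assay. The hydroxy group also cannot be separated from the other groups at this position, since a 1.3-fold higher number from compound 3 to compound 4 (0.10 log units; within the scatter) and a 1.1-fold higher number from compound 1 to compound 4 (0.05 log units; within the scatter) are both within the scatter too. With hydrogen, methoxy, chloro and hydroxy now compared on this aromatic carbon, none of the steps among these four compounds has left the scatter.

As far as these compounds go, whether an amine or a carboxylic acid on this aromatic carbon, or a longer chain on the oxygen, would produce a step beyond the scatter remains open, as does whether changes elsewhere on the shared core would do so. Nothing available offers an explanation for these readings.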